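This account rests on a few compounds, and the source may have more. Where it says the series, first, only, none or still open, it means among the compounds named here.

Measured so far in an ADME assay on MT4 cells (Homo sapiens) for cytotoxicity, read by MTT assay, with a stated time of 5 days; a higher number here means that more compound is tolerated, a lower number that less compound is tolerated
Compound 1 `Cc1cc(C)cc(S(=O)(=O)n2c(SCC(=O)Nc3ccccc3S(N)(=O)=O)nc3ccccc32)c1` gives 25000 nM
Compound 2 `COC(=O)c1ccc(NC(=O)CSc2nc3ccccc3n2S(=O)(=O)c2cc(C)cc(C)c2)cc1` gives 10000 nM
Compound 3 `Cc1cc(C)cc(S(=O)(=O)n2c(SCC(=O)Nc3ccc(S(N)(=O)=O)cc3)nc3ccccc32)c1` gives 30900 nM

Compound 3 stands at 30900 nM and cannot be told apart from compound 1 (a 1.2-fold higher number from compound 1 to compound 3 (0.09 log units; within the scatter)), while compound 2 lies clearly lower (a 3.1-fold higher number from compound 2 to compound 3 (0.49 log units; beyond the scatter)). Compound 4 `Cc1cc(C)cc(S(=O)(=O)n2c(SCC(=O)Nc3ccccc3Cl)nc3ccccc32)c1` carries 2-chlorophenyl in place of 4-sulfamoylphenyl on an amide-type nitrogen. Among the compounds with values here, the nearest guide is compound 2, the only measured compound without a sulfamoyl group, and its steps are modest (a 2.5-fold lower number from compound 1 to compound 2 (0.40 log units; beyond the scatter)). Within the data shown here, no compound with a chlorine has been measured, so a modest step down in this assay is expected. Among the measured compounds shown here, the expected change is a 2.4-fold lower number from compound 3 to compound 4 (0.38 log units; beyond the scatter) and no larger step is foreseen. For compound 4 the estimated value is 13000 nM (expected range 5000 nM to 32000 nM).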

Compound 4, half-maximal cytotoxic concentration: 107000 nM
For compound 4 the middle estimate is 8.2-fold (0.92 log units) below the measured one; measured number above the stated range.
By their numbers in this assay, from the lowest: compound 2; then compounds 1 and 3 (each within the scatter of the next); then compound 4.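

In this assay, within the data shown here, the 2-chlorophenyl group on the amide-type nitrogen gives a higher number than any earlier group there, so this position can raise the tolerated concentration well past the earlier compounds (a 3.5-fold higher number from compound 3 to compound 4 (0.54 log units; beyond the scatter)) and (an 11-fold higher number from compound 2 to compound 4 (1.03 log units; beyond the scatter)). Chloro in place of sulfamoyl on an aromatic carbon, a change in one place only, also raises the number beyond the scatter (a 4.3-fold higher number from compound 1 to compound 4 (0.63 log units; beyond the scatter)). No measured evidence bearing on this result is available. The compounds shown leave open whether a plain phenyl, a fluoro or a methyl group in place of the chloro would give a similar number.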